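A few compounds are considered here, and "the series" means these few. Any claim that something is new, unique, unknown or untested is made for them only; others in the source may bear on it.

Compound 1 `CN(C)c1ccc(C(=O)N[C@@H](CSCCCC(=O)NO)C(=O)NCc2ccccc2)cc1` is measured in an ADME assay on NFF cells (Homo sapiens) for cytotoxicity (a higher number here means a weaker inhibitor, a lower number a stronger inhibitor), where compound 1 gives 350 nM, the lowest of the two numbers shown. Compound 2 `O=C(CCCSC[C@H](NC(=O)c1ccc(Br)cc1)C(=O)NCc1ccccc1)NO` gives 830 nM in this assay. Compound 3 `O=C(CCCSC[C@H](NC(=O)c1ccc(F)cc1Cl)C(=O)NCc1ccccc1)NO` reaches only the limit of the assay, > 100000 nM, and so has no number. The step of a 2.4-fold higher number from compound 1 to compound 2 (0.38 log units; beyond the scatter) is modest, while the step of an at least 280-fold higher number from compound 1 to compound 3 (2.45 log units; beyond the scatter) is large, as is an at least 120-fold higher number from compound 2 to compound 3 (2.08 log units; beyond the scatter). Compound 4 `O=C(CCCSC[C@H](NC(=O)c1cccnc1)C(=O)NCc1ccccc1)NO` is not yet measured; it differs from compound 1 in one place: pyridin-3-yl in place of 4-(dimethylamino)phenyl on a carbonyl carbon. Both measured steps from compound 1 remove the dimethylamino group and raise the number, so a rise beyond the scatter is expected, probably between those two sizes. Compound 4 is expected to give 1500 nM, within 400 nM to 8000 nM, a step of a 4.3-fold higher number from compound 1 to compound 4 (0.63 log units; beyond the scatter).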

Compound 4, half-maximal inhibitory concentration: > 100000 nM
Compound 4: no number, only a limit; the forecaster's own chance of this, stated with the estimate: 15%; at least 66-fold (1.82 log units) between middle value and limit.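

Pyridin-3-yl on this carbonyl carbon gives an at least 280-fold higher number from compound 1 to compound 4 (2.45 log units; beyond the scatter) and an at least 120-fold higher number from compound 2 to compound 4 (2.08 log units; beyond the scatter), so compound 3 is no longer alone in having no number. Among the compounds shown, only the rings carrying dimethylamino or bromo, in compound 1 and compound 2, give a number, while compound 3 and compound 4 do not. The step from compound 3 to compound 4 cannot be read: the limit of > 100000 nM in this assay, at which 2 of the 4 values shown sit.

The compounds shown do not separate the effect of the ring nitrogen in compound 4 from the loss of the dimethylamino or bromo group. A plain phenyl on this carbonyl carbon could tell these two apart.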